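The source may hold more compounds than are shown below. What is called first, only, known or untested is meant among the compounds shown, and "the series" means these compounds.

Measured in a functional assay on the whole organism for inhibition, with Rattus norvegicus as the target, at a dose of 30 mg/kg; on this read-out lower numbers stand for less inhibition and higher numbers for more inhibition at the one dose given (going by the name of the read-out):
Compound 1 `N#Cc1cccc(-c2nc3ncccc3o2)c1`: 21%
Compound 2 `Clc1ccc(-c2nc3cccnc3o2)cc1`: 14%
Compound 3 `Clc1cccc(-c2nc3ncccc3o2)c1`: 32%

Compound 3 gives the highest number of the three. Compound 2 sits within the scatter of compound 1 and beyond the scatter below compound 3. Among the measured compounds shown here, the only step between two measured compounds that differ in one place is a number 11 percentage points lower from compound 3 to compound 1 (beyond the scatter); it rests on (cyano in place of chloro on an aromatic carbon).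

Compound 4 `N#Cc1ccc(-c2nc3cccnc3o2)cc1` is not yet measured. It differs from compound 2 by cyano in place of chloro on an aromatic carbon. This is the same kind of change as that from compound 3 to compound 1, but the place is not the same: meta in compound 1, para in compound 4. How the core of compound 2 differs from that of compound 3 is not broken down here.

For the measured compounds named here, for compound 4 the expected step is a number 9 percentage points lower from compound 2 to compound 4 (within the scatter), a similar downward size, because a number 11 percentage points lower from compound 3 to compound 1 (beyond the scatter) is the one measured example of this change. In this assay compound 4 is estimated at 5%, expected between -5% and 18%.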

Compound 4, a percentage reported as inhibition, in the whole organism at one dose (the size of the read-out at that dose, not a potency): 17%
For compound 4 the middle estimate is 12 percentage points below the measured one; low and high end bracket the measured number.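

Working from this assay, cyano in place of chloro on an aromatic carbon gives a number 3 percentage points higher from compound 2 to compound 4 (within the scatter). Set beside the earlier step, the two results do not separate the cores: the same change on two cores in this assay, a number 11 percentage points lower (beyond the scatter) from compound 3 to compound 1 and a number 3 percentage points higher (within the scatter) from compound 2 to compound 4, 14 percentage points apart, within the scatter of two such steps. This shows no measurable dependence of the change on the core, but it does not establish that the change carries over with a common size, since each core supplies a single pair and the group does not sit in the same place in the two pairs.

Only chloro and cyano are shown on the aromatic ring, and all readings come from one dose. Going by these compounds, how an amine, a carboxylic acid or a longer chain at that carbon would read remains open.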